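The source may hold more compounds than are shown below. What is called first, only, known or untested is meant among the compounds shown, and "the series" means these compounds.

Compound 1, `Brc1cn2ccnc2c(-c2ccc3ncn(C4CCCCC4)c3c2)n1`: 26.8%
Compound 2, `O=Cc1ccc(-c2cn3ccnc3c(-c3ccc4ncn(C5CCCCC5)c4c3)n2)cc1`: 47.5%
Compound 3, `c1cn2cc(-c3ccsc3)nc(-c3ccc4ncn(C5CCCCC5)c4c3)c2n1`: 14.3%

In a functional assay on SR cells (Homo sapiens) for inhibition, read by sulforhodamine B assay, with a stated time of 48 h, tested at 10 uM (on this read-out lower numbers stand for less inhibition and higher numbers for more inhibition at the one concentration tested (going by the name of the read-out)), compound 1 gives 26.8% and stands second highest of the three numbers. Its nearest neighbour is the lower number, a number 12.5 percentage points lower from compound 1 to compound 3 (beyond the scatter); the furthest is the higher number, a number 20.7 percentage points higher from compound 1 to compound 2 (beyond the scatter). The two measured companions differ from compound 1 only at the bromo on the shared core, and they pull in opposite directions, the gap between them being a number 33.2 percentage points lower from compound 2 to compound 3 (beyond the scatter).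

Compound 4, `COc1ccccc1-c1cn2ccnc2c(-c2ccc3ncn(C4CCCCC4)c3c2)n1`, is the next step from compound 1. The change is 2-methoxyphenyl in place of bromo on an aromatic carbon. Both measured steps from compound 1 bear on it, since each also swaps the bromo for a ring: the aryl ring brought a modest gain, a number 20.7 percentage points higher from compound 1 to compound 2 (beyond the scatter), whereas the thiophene ring brought a modest loss, a number 12.5 percentage points lower from compound 1 to compound 3 (beyond the scatter). With 2-methoxyphenyl, a six-membered aromatic ring of carbon only, entering in place of bromo, the step is expected to resemble the aryl case more than the thiophene case, so a modest rise is expected for compound 4, a number 11.2 percentage points higher from compound 1 to compound 4 (beyond the scatter), though the spread between the two measured steps leaves the size uncertain. Compound 4 is therefore estimated at 38%, in a range from 18% to 58%.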

Compound 4, a percentage reported as inhibition, at one concentration (the size of the read-out at that concentration, not a potency): 26.3%
The estimate for compound 4 lay 11.7 percentage points above the measured number, and the stated range covers the measured number.
By their numbers in this assay, from the lowest: compound 3; then compounds 4 and 1 (each within the scatter of the next); then compound 2.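

In this assay, 2-methoxyphenyl and bromo on this aromatic carbon cannot be told apart (a number 0.5 percentage points lower from compound 1 to compound 4 (within the scatter)), so replacing the bromo with a ring does not by itself bring either the gain or the loss seen earlier. A six-membered aromatic ring of carbon only is also no assurance of a gain at this position: 2-methoxyphenyl and 4-formylphenyl are both such rings, yet they give clearly different numbers (a number 21.2 percentage points lower from compound 2 to compound 4 (beyond the scatter)), which places the difference in what the ring carries or where it carries it. The 2-methoxyphenyl group still stands clear of thiophen-3-yl (a number 12 percentage points higher from compound 3 to compound 4 (beyond the scatter)), so the ring entering here does matter, with the thiophene compound lowest of these compounds and 4-formylphenyl highest.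

The compounds shown leave open whether the formyl group or its place on the ring sets compound 2 apart, and how an unsubstituted phenyl, a 4-aminophenyl or a 4-carboxyphenyl group would read at this position. No measurement given here accounts for the differences among these groups.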